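The source may hold more compounds than are shown below. What is called first, only, known or untested is meant among the compounds shown, and "the series" means these compounds.

Measured compounds in the series:
compound 1, `CC/C(=C(/c1ccc(/C=C/C(=O)O)cc1)c1[nH]c2ccccc2c1Br)c1ccc(F)cc1Cl`, with 8.53 nM
compound 2, `CC/C(=C(/c1ccc(/C=C/C(=O)O)cc1)c1[nH]c2ccccc2c1Cl)c1cc(Cl)sc1Cl`, with 20 nM
compound 3, `CC/C(=C(/c1ccc(/C=C/C(=O)O)cc1)c1[nH]c2ccccc2c1C#N)c1ccc(F)cc1Cl`, with 4.85 nM

In a functional assay on MCF7 cells (Homo sapiens) for antiproliferative activity, read by luminescence and CellTiter-Glo, with a stated time of 5 days (on this read-out higher numbers stand for weaker inhibition and lower numbers for stronger inhibition), compound 3 gives the lowest of the three numbers. Compound 1 stands nearest to it, and the gap between the two lies within the scatter, so no order between compound 3 and compound 1 can be read from these numbers. Compound 2 stands furthest from compound 3, and that gap lies beyond the scatter.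

The next compound, compound 4, `CC/C(=C(/c1ccc(/C=C/C(=O)O)cc1)c1[nH]c2ccccc2c1C)c1ccc(F)cc1Cl`, differs from compound 3 in one place: methyl in place of cyano on an aromatic carbon. Among the compounds with values here, only one measured step touches this position, namely a 1.8-fold lower number from compound 1 to compound 3 (0.25 log units; within the scatter), an exchange of one small group for another at the same ring carbon that left the number essentially unchanged. Within the data shown here, no measured step concerns a methyl at this position, so the expectation rests on that single exchange alone. On that basis no step beyond the scatter is expected in this assay for compound 4, in either direction.

Compound 4 is therefore estimated at 8 nM, with a range from 3 nM to 20 nM. This estimate means an expected step of a 1.6-fold higher number from compound 3 to compound 4 (0.22 log units; within the scatter) from compound 3.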

Compound 4, half-maximal inhibitory concentration: 4.78 nM
Compound 4: middle estimate off by 1.7-fold (0.22 log units), on the high side; the range from low to high includes it.
By their numbers in this assay, from the lowest: compounds 4, 3 and 1 (each within the scatter of the next); then compound 2.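

Bromo, cyano and methyl can now be compared at the aromatic carbon two ring bonds from the ring nitrogen, with the rest of the structure unchanged. In this assay both new steps, a 1.0-fold lower number from compound 3 to compound 4 (0.01 log units; within the scatter) and a 1.8-fold lower number from compound 1 to compound 4 (0.25 log units; within the scatter), lie within the scatter, so the three groups cannot be ordered by these numbers. The earlier compounds offered only the exchange of bromo and cyano, whereas methyl has no triple bond and no hydrogen-bond acceptor, and neither difference from cyano separates compound 3 from compound 4 in this assay; no measurement at hand explains why these groups read alike.

Compound 2 carries chloro at this carbon but also differs from the others in a second place, so it does not extend the comparison at this position. The compounds shown leave open whether this carbon accepts an unsubstituted hydrogen, an amine, a carboxylic acid or a longer chain such as propyl with an equally small step, and whether the same holds in the other structural contexts of the series.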